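Moving from an aryl to a benzyl amine on the thienopyrimidine

A few compounds are considered here, and "the series" means these few. Any claim that something is new, unique, unknown or untested is made for them only; others in the source may bear on it.

Of the compounds shown here, three of a shared core have been measured in a functional assay on L02 cells (Homo sapiens) for inhibition, read by Griess assay, with stated times of 1 h and 24 h; on this read-out higher numbers stand for weaker inhibition and lower numbers for stronger inhibition. Compound 1 `CNc1nc(/C=C/c2ccco2)nc2ccsc12` gives 811000 nM in this assay. Compound 2 `Fc1ccc(CNc2nc(/C=C/c3ccco3)nc3ccsc23)cc1` gives > 1000000 nM in this assay, and that is a limit of the assay rather than a number. Compound 3 `COc1cc(/C=C/c2nc(Nc3ccc(C(C)C)cc3)c3sccc3n2)cc(OC)c1OC` gives 370000 nM in this assay, the lower of the two numbers; the step to compound 1 is beyond the usual scatter.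

Compound 4 `COc1ccc(CNc2nc(/C=C/c3cc(OC)c(OC)c(OC)c3)nc3ccsc23)cc1` has not been measured. It differs from compound 3 by 4-methoxybenzyl in place of 4-isopropylphenyl on a nitrogen on an aromatic ring. Among the measured compounds shown here, only one measured step is similar in kind: the placing of a benzyl-type group on the amine nitrogen, where the step from compound 1 to compound 2 reads an at least 1.2-fold higher number from compound 1 to compound 2 (0.09 log units; that floor lies within the scatter), with compound 2 ending at the limit of > 1000000 nM in this assay, at which 1 of the 3 values shown sits. For the measured compounds named here, that step tells little about its own size, and no measured pair trades an aryl for a benzyl group directly. Compound 4 is therefore expected to give a higher number than compound 3, with a step of about a 1.9-fold higher number from compound 3 to compound 4 (0.28 log units; within the scatter) in this assay, and a real chance of a limit.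

Compound 4 is thus estimated at 700000 nM in this assay, within a range of 300000 nM to 1500000 nM.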

Compound 4, half-maximal inhibitory concentration: > 1000000 nM
Compound 4 ended at the assay's limit (the forecaster's own chance of this, stated with the estimate: 30%); at least 1.4-fold (0.15 log units) between middle value and limit.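

In this assay, the exchange of 4-isopropylphenyl for 4-methoxybenzyl on the nitrogen gives an at least 2.7-fold higher number from compound 3 to compound 4 (0.43 log units; beyond the scatter), so this position now has a direct trade of an aryl for a benzyl-type group, and the change weakens inhibition. The earlier step at this nitrogen, an at least 1.2-fold higher number from compound 1 to compound 2 (0.09 log units; that floor lies within the scatter), could not show this, since its floor stayed within the usual scatter. The value of compound 4 is a limit of the assay and not a number, which leaves the new step with only a floor, and among the compounds shown, only the two with a benzyl-type group on this nitrogen end at that limit: the limit of > 1000000 nM in this assay, at which 2 of the 4 values shown sit.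

The change alters two things at once, the 4-isopropyl group giving way to a 4-methoxy group and the ring moving one carbon away from the nitrogen, and the compounds shown do not separate these two parts. From the compounds shown here alone, a 4-methoxyphenyl or a 4-isopropylbenzyl group on the same nitrogen would tell them apart, and whether a longer chain between nitrogen and ring would weaken inhibition further, or how far, stays open.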